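The compounds below may be only part of what the source reports. "The series", "measured", "known", "first", "only" and "open" are said of these compounds alone.

In a functional assay on Ehrlich cells (Mus musculus) for cytotoxicity, read by trypan blue exclusion, with a stated time of 2 h (on this read-out lower numbers stand for stronger inhibition and higher numbers for weaker inhibition), compound 1 `N#CC1=C(N)N(c2ccc(S(N)(=O)=O)cc2)C2=C(C(=O)CCC2)C1c1ccc(Cl)cc1Cl` gives 25 ug/mL and compound 2 `CC(Cl)CC(=O)NC1=C(C#N)C(c2ccc(Cl)cc2Cl)C2=C(CCCC2=O)N1c1ccc(S(N)(=O)=O)cc1` gives 25 ug/mL. Compound 3 `N#CC1=C(/N=C/c2ccc([N+](=O)[O-])cc2[N+](=O)[O-])N(c2ccc(S(N)(=O)=O)cc2)C2=C(C(=O)CCC2)C1c1ccc(Cl)cc1Cl` reaches only a limit of the assay, > 100 ug/mL, so its true position on the scale is not known.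

Compound 4 `CCO/C=N/C1=C(C#N)C(c2ccc(Cl)cc2Cl)C2=C(CCCC2=O)N1c1ccc(S(N)(=O)=O)cc1` has not been measured, and its difference from compound 3 is ethoxy in place of 2,4-dinitrophenyl on a carbon with a double bond to nitrogen. Among the measured compounds shown here, no measured step covers this exchange. For the measured compounds named here, the only one available is no change at the digits printed from compound 1 to compound 2 (within the scatter), with (2-chloropropyl)carbonyl in place of hydrogen on an amine nitrogen, and it bears on the case only indirectly. It does show that the shared core kept its reading in this assay with a different group on that nitrogen. Compound 4 loses the 2,4-dinitrophenyl group found in compound 3, so a reading nearer those of compound 1 and compound 2 is expected, in the direction of stronger inhibition. The expected change is an at least 2.8-fold lower number from compound 3 to compound 4 (0.45 log units; beyond the scatter). For compound 4, the estimated value is 35 ug/mL, within an expected range of 12 ug/mL to 100 ug/mL.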

Compound 4, half-maximal inhibitory concentration: > 100 ug/mL
Compound 4: no number, only a limit (the forecaster's own chance of this, stated with the estimate: 20%); middle value at least 2.8-fold (0.45 log units) from the limit.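

In this assay compound 4 gives > 100 ug/mL, which is a limit of the assay and not a number. The earlier pair suggested that the group on this double-bonded ring carbon could vary without effect, but the reading does depend on it, with an at least 4.0-fold higher number from compound 1 to compound 4 (0.60 log units; beyond the scatter) and an at least 4.0-fold higher number from compound 2 to compound 4 (0.60 log units; beyond the scatter). The exchange of 2,4-dinitrophenyl for ethoxy cannot be read because compound 3 and compound 4 stand at the same bound: the limit of > 100 ug/mL in this assay, at which 2 of the 4 values shown sit.

The compounds shown leave open whether any group on the carbon with a double bond to nitrogen can restore a reading like those of compound 1 and compound 2, for instance an amine or a methyl in place of ethoxy. They also leave open whether an unsubstituted phenyl there would escape the limit.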